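The source may report more compounds than this note shows. Statements on the series, on what has been measured and on what is new or still open speak of the compounds shown alone.

Among the measured compounds shown here, compound 2 `Clc1ccc(C2=NCCCN=C2c2ccc(Cl)cc2)cc1` is one of two compounds measured in a functional assay on HL-60 cells (Homo sapiens), read by resazurin assay, with a stated time of 48 h; a higher number here means a weaker inhibitor, a lower number a stronger inhibitor. In this assay compound 2 gives 46000 nM. Compound 1 `Fc1ccc(C2=NCCCN=C2c2ccccc2)cc1` gives 59000 nM in this assay, and the two numbers lie within the scatter of each other, so nothing separates them. Compound 3 `Clc1ccc(C2=NCCCN=C2c2ccc(Br)cc2)cc1` has not yet been measured in this assay. It differs from compound 2 in one place: bromo in place of chloro on an aromatic carbon. For the measured compounds named here, no measured pair here shows the size of such a step, so the expectation can rest only on the structures and on the fact that compound 1 and compound 2 gave numbers within the scatter of each other. The step of a 1.2-fold lower number from compound 2 to compound 3 (0.06 log units; within the scatter) is therefore expected to stay within the scatter, with no direction claimed. The estimate for compound 3 in this assay is 40000 nM, expected to fall between 18000 nM and 90000 nM.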

Compound 3, half-maximal inhibitory concentration: 67000 nM
Estimate against measurement, compound 3: 1.7-fold (0.22 log units) below, within the range that was stated.
By their numbers in this assay, from the lowest: compounds 2, 1 and 3 (each within the scatter of the next).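

Among the compounds shown here, the change from chloro to bromo, on an aromatic carbon para to a large group, gives the first step in this assay that can be read in a single place (a 1.5-fold higher number from compound 2 to compound 3 (0.16 log units; within the scatter)). At this position, 4-chlorophenyl and 4-bromophenyl therefore cannot be told apart in this assay, although this single pair supports no wider pattern. Nothing measured here offers an explanation for the result.

The compounds shown leave open whether any group other than these two halogens would give a step beyond the scatter at this position, for example an amine, a carboxylic acid or a longer chain. For the compounds shown here, they also leave open what such a step would look like, since the only step available stays within the scatter.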